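Replacing the furan side group on compound 2

The compounds below may be only part of what the source reports. "The series", "measured", "known", "first", "only" and "open" are said of these compounds alone.

Compound 1 `Cc1ccccc1Nc1nc(Nc2ccc(N3CCN(C)CC3)cn2)ncc1Cl`: 5210 nM
Compound 2 `CN1CCN(c2ccc(Nc3ncc(Cl)c(NCc4ccco4)n3)nc2)CC1`: 21300 nM

Among the compounds with values here, in a functional assay on MCF7 cells (Homo sapiens) for inhibition, read by CCK-8 assay, with a stated time of 48 h (a lower number here means a stronger inhibitor of growth, a higher number a weaker inhibitor of growth), only two numbers are known so far. Within the data shown here, compound 2 has the higher, 21300 nM against the value of its only neighbour, and compound 1 sits at 5210 nM on the same scale.

The next compound is compound 3 (`Cc1ccc(Nc2nc(Nc3ccc(N4CCN(C)CC4)cn3)ncc2Cl)cc1`), which has 4-methylphenyl in place of (furan-2-yl)methyl on a nitrogen on an aromatic ring.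

Among the measured compounds shown here, one measured step bears on this change. It is modest and beyond the scatter: a 4.1-fold higher number from compound 1 to compound 2 (0.61 log units; beyond the scatter) with (furan-2-yl)methyl replacing 2-methylphenyl at the same place. For the measured compounds named here, compound 3 runs that exchange in reverse, but 4-methylphenyl enters rather than 2-methylphenyl, and no measured pair compares those two groups. A step of similar size towards a lower number is therefore expected in this assay, with wide uncertainty.

The expected change is a 3.9-fold lower number from compound 2 to compound 3 (0.59 log units; beyond the scatter) on this estimate. For compound 3 the estimated value is 5500 nM with 1800 nM to 15000 nM as the expected range.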

Compound 3, concentration for 50% growth inhibition: 11400 nM
The estimate for compound 3 lay 2.1-fold (0.32 log units) below the measured number; measured number inside the range.
By their numbers in this assay, from the lowest: compound 1; then compounds 3 and 2 (each within the scatter of the next).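

In this assay, the exchange at this nitrogen gives a 1.9-fold lower number from compound 2 to compound 3 (0.27 log units; within the scatter) so the result does not separate the 4-methylphenyl group from the (furan-2-yl)methyl group. Within the data shown here, the other new comparison is the first to hold an aromatic ring of carbon only constant at this place while moving the methyl: a 2.2-fold higher number from compound 1 to compound 3 (0.34 log units; beyond the scatter) is a modest change that lies beyond the scatter. The gap between compound 1 and compound 2 therefore cannot be read as a simple contrast between a methylphenyl group and (furan-2-yl)methyl, since compound 3 also carries a methylphenyl group, and, of the three compounds, only compound 1, with 2-methylphenyl, has a number clearly below that of compound 2.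

No supporting data on the compounds bear on why the methyl placement matters here. Whether the difference reflects the 2-methylphenyl group specifically remains open, as the compounds shown do not include a plain phenyl or 3-methylphenyl group at this nitrogen, and a 2-chlorophenyl group would test whether another group can stand in for that methyl.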